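Solubility notes: dihydroindolyl replacement for fluorophenyl in compound 1

The source may hold more compounds than are shown below. What is called first, only, known or untested is meant among the compounds shown, and "the series" means these compounds.

Measured so far:
compound 1, `CNC(=O)c1cc(C(=O)NC2CC2)cn(Cc2cccc(F)c2)c1=O` — >= 133 ug/mL
compound 2, `CNC(=O)c1cc(C(=O)NC(C)C)cn(Cc2ccccc2)c1=O` — >= 136 ug/mL

Compound 1 is `CNC(=O)c1cc(C(=O)NC2CC2)cn(Cc2cccc(F)c2)c1=O`. In a physicochemical assay for solubility (a higher number here means a more soluble compound, a lower number a less soluble compound), compound 1 gives >= 133 ug/mL, which is a limit of the assay and not a number, as the limit of >= 133 ug/mL in this assay, at which 1 of the 2 values shown sits, records. Compound 2 is `CNC(=O)c1cc(C(=O)NC(C)C)cn(Cc2ccccc2)c1=O`. In this assay compound 2 gives >= 136 ug/mL, again a limit of the assay rather than a number, as the limit of >= 136 ug/mL in this assay, at which 1 of the 2 values shown sits, records. Where compound 1 stands on these figures is therefore only a limit, and the one further value shown is also a limit, so no step between measured compounds can be counted and no ranking is possible.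

The unmeasured compound 3 is `CNC(=O)c1cc(C(=O)NC2CC2)cn(Cc2cccc3c2CCN3)c1=O`. It differs from compound 1 in one place: 2,3-dihydro-1H-indol-4-yl in place of 3-fluorophenyl on a saturated chain carbon bound to an aromatic nitrogen. Nothing measured here speaks to what this change does to solubility, so the expectation for compound 3 rests on the limit recorded for compound 1 alone. The step from compound 1 to compound 3 is expected to be an at least 1.0-fold lower number from compound 1 to compound 3 (0.00 log units; that floor lies within the scatter), that is, none beyond the usual scatter. Compound 3 is therefore estimated to give 130 ug/mL in this assay, within a range of 40 ug/mL to 150 ug/mL, quite possibly reported again as a limit.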

Compound 3, solubility: >= 184 ug/mL
Compound 3 gave a limit, no number; the forecaster's own chance of this, stated with the estimate: 60%; middle value at least 1.4-fold (0.15 log units) away from the limit.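

Compound 1 and compound 3 are both recorded in this assay only as limits of the assay and not as numbers; the step between them cannot be read. The compounds shown leave open whether 2,3-dihydro-1H-indol-4-yl in place of 3-fluorophenyl changes the read-out at all, and how far each compound's true solubility lies from its limit.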